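Cytotoxicity Check on a Fourth Analogue of a Shared Core

This account rests on a few compounds, and the source may have more. Where it says the series, first, only, none or still open, it means among the compounds named here.

Compound 3 `COCCCNc1nc(N)nc2ccn(Cc3ccccn3)c12` is one of three compounds on a shared core tested in an ADME assay on HEK293 cells (Homo sapiens) for cytotoxicity, read by ATP content, with a stated time of 6 h; a higher number here means that more compound is tolerated, a lower number that less compound is tolerated. In this assay compound 3 gives > 24000 nM, which is a limit of the assay rather than a number. Compound 1 `CCCCNc1nc(N)nc2ccn(CC=C(C)C)c12` gives > 24000 nM in this assay, also a limit. Compound 2 `CCCCNc1nc(N)nc2ccn(Cc3ccncc3)c12` gives > 24000 nM in this assay, again a limit. Going by the values given here, the one step between measured compounds, a step that the two limits leave unreadable from compound 1 to compound 2, therefore cannot be read, and the limit of > 24000 nM in this assay, at which 3 of the 3 values shown sit, sums up all that is known. Compound 4 `Cc1cc(CNc2nc(N)nc3ccn(Cc4ccccn4)c23)no1` differs from compound 3 by 5-methyl-1,2-oxazol-3-yl in place of 2-methoxyethyl on a saturated chain carbon bound to a nitrogen on an aromatic ring. Among the compounds with values here, no measured step bears on this change, so no direction can be drawn from the numbers. The expected step is a step that the limit leaves unreadable from compound 3 to compound 4, within the scatter. Compound 4 is therefore estimated at 30000 nM, between 12000 nM and 80000 nM.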

Compound 4, half-maximal cytotoxic concentration: > 24000 nM
Compound 4: only a limit was reported (the forecaster's own chance of this, stated with the estimate: 80%); the middle value lies beyond the limit too.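

Going by these compounds alone, compound 3 and compound 4 each give only a limit of the assay, not a number, so no step between them can be read.

The true half-maximal cytotoxic concentration of every compound shown stays open in this assay, where all share one limit: the limit of > 24000 nM in this assay, at which 4 of the 4 values shown sit.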